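The compounds below may be only part of what the source reports. "The series", "measured", "known", "first", "only" and "open" are said of these compounds alone.

Measured so far in an ADME assay on microsomes from liver (Canis lupus familiaris) for metabolic stability, with a stated time of 10 min; on this read-out lower numbers stand for a less stable compound and higher numbers for a more stable compound:

Compound 1 `FC(F)(F)c1ccccc1-c1ccc2[nH]c(C3=NC4(CCCCC4)CO3)nc2c1` gives 32%
Compound 2 `FC(F)Oc1ccccc1-c1ccc2[nH]c(C3=NOC4(CCCCC4)C3)nc2c1` gives 81%
Compound 3 `Fc1cc(-c2ccccc2C(F)(F)F)cc2nc(C3=NOC4(CCCCC4)C3)[nH]c12` gives 87%

Compound 3 stands at the high end of these numbers. It is level, within the scatter, with compound 2 and lies beyond the scatter from compound 1.

The next compound, compound 4 `FC(F)(F)c1ccccc1-c1cc(Br)c2[nH]c(C3=NOC4(CCCCC4)C3)nc2c1`, has not yet been measured. It carries bromo in place of fluoro on an aromatic carbon and is otherwise the same as compound 3.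

Going by the values given here, no two measured compounds differ in one place only, so no measured step shows what such a swap does. Compound 2 at 81% and compound 3 at 87% differ in more than one place and still sit within the scatter of each other, which gives only a weak reason to expect little movement in this assay here. The estimated a number 9 percentage points lower from compound 3 to compound 4 (within the scatter) is a small fall, probably not clearly beyond the scatter. Compound 4 is expected at 78% with a range from 60% to 92% on this estimate.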

Compound 4, percent of the compound remaining: 74%
The estimate for compound 4 lay 4 percentage points above the measured number; low and high end bracket the measured number.
By their numbers in this assay, from the lowest: compound 1; then compounds 4, 2 and 3 (each within the scatter of the next, the first and the last beyond it).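

Bromo in place of fluoro on this aromatic carbon, ortho to a fused ring, gives the first step in this set that changes one place only: in this assay there is a number 13 percentage points lower from compound 3 to compound 4 (beyond the scatter) and that fall is modest. The read-out therefore responds to which halogen sits at this position, although compound 4 at 74% still lies far from the low end of the set. No measurement at hand gives a reason for this fall.

On these data alone, what a chloro group, a methoxy group, a nitrile or an amine would do at this position remains open, as does the result with plain hydrogen there. As far as these compounds go, it is also open whether the same swap would give a similar step with the difluoromethoxy group of compound 2 in place of the trifluoromethyl group.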